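This account rests on a few compounds, and the source may have more. Where it says the series, first, only, none or still open, it means among the compounds named here.

Compound 3 `COc1ccc(-c2cn(-c3cccc(C(=O)/C=C/c4cc(OC)c(OC)c(OC)c4)c3)c(=O)[nH]2)cc1` gives 4950 nM in a functional assay on SF-295 cells (Homo sapiens) for inhibition; a lower number here means a stronger inhibitor of growth, a higher number a weaker inhibitor of growth. Among the three compounds measured so far it holds the second highest number: compound 2 `COc1cc(/C=C/C(=O)c2cccc(-n3cc(-c4ccccc4)[nH]c3=O)c2)cc(OC)c1OC` gives 1900 nM in this assay, while compound 1 `COc1cc(/C=C/C(=O)c2cccc(-n3cc(-c4ccc(Cl)cc4)[nH]c3=O)c2)cc(OC)c1OC` gives 24300 nM. Compound 4 `COc1cc(/C=C/C(=O)c2cccc(-n3cc(-c4cc(OC)c(OC)c(OC)c4)[nH]c3=O)c2)cc(OC)c1OC` differs from compound 3 in a single place: 3,4,5-trimethoxyphenyl in place of 4-methoxyphenyl on an aromatic carbon. The measured step that speaks most directly to this change is the one in which a single methoxy group replaced a hydrogen on the same aromatic ring, a 2.6-fold higher number from compound 2 to compound 3 (0.42 log units; beyond the scatter), a modest rise in the number. The chloro compound stands further away from this question, but its steps, a 13-fold lower number from compound 1 to compound 2 (1.11 log units; beyond the scatter) and a 4.9-fold lower number from compound 1 to compound 3 (0.69 log units; beyond the scatter), show that what sits on this ring can move the number a good deal in either direction. Since one added methoxy already raised the number, adding two more is expected to push it up again by a modest amount rather than to bring it down, so for compound 4 a step of a 1.6-fold higher number from compound 3 to compound 4 (0.21 log units; within the scatter) in this assay is expected. The estimate for compound 4 is therefore 8000 nM, with a range from 3000 nM to 25000 nM.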

Compound 4, concentration for 50% growth inhibition: 4960 nM
Compound 4: middle estimate off by 1.6-fold (0.21 log units), on the high side; low and high end bracket the measured number.
By their numbers in this assay, from the lowest: compound 2; then compounds 3 and 4 (each within the scatter of the next); then compound 1.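

In this assay, among these compounds, replacing 4-methoxyphenyl with 3,4,5-trimethoxyphenyl gives a 1.0-fold higher number from compound 3 to compound 4 (0.00 log units; within the scatter), so compound 3 and compound 4 cannot be told apart, even though the first methoxy group on this ring did shift the number. The larger group gives the same picture against the other two rings: a 2.6-fold higher number from compound 2 to compound 4 (0.42 log units; beyond the scatter) relative to plain phenyl, and a 4.9-fold lower number from compound 1 to compound 4 (0.69 log units; beyond the scatter) relative to 4-chlorophenyl, so compound 4 stands where compound 3 stands among these compounds. Nothing available here explains why the two added methoxy groups leave no visible mark on growth inhibition.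

The rings shown carry only hydrogen, chloro or methoxy, so it remains open how this position would respond to a quite different group, such as an amine, a carboxylic acid or a longer chain like butoxy. On these data alone, it also remains open whether any group here could bring the number below that of compound 2, at 1900 nM, and whether the match between compound 3 and compound 4 would hold in other cell lines.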